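A few compounds are considered here, and "the series" means these few. Any claim that something is new, unique, unknown or untested is made for them only; others in the source may bear on it.

Compound 1, `COc1cc2c(Oc3ccc(NC(=O)c4nn(-c5ccc([N+](=O)[O-])cc5)c(=O)c5ccccc45)cc3F)ccnc2cc1OCCCN1CCN(C)CC1`, gives 980 nM in a functional assay on NCI-H460 cells (Homo sapiens) for cytotoxicity, read by MTT assay, with a stated time of 72 h; a lower number here means a stronger inhibitor, a higher number a weaker inhibitor.
Compound 2, `COc1cc2c(Oc3ccc(NC(=O)c4nn(-c5ccccc5F)c(=O)c5ccccc45)cc3F)ccnc2cc1OCCCN1CCCCC1`, gives 160 nM in this assay.

Of the two measured compounds, compound 2 holds the lower number; compound 1 sits at the higher value, a gap that is beyond the usual scatter. The two differ in two places at once, so no single change can be read off from them. Compound 3, `COc1cc2c(Oc3ccc(NC(=O)c4nn(-c5ccc([N+](=O)[O-])cc5)c(=O)c5ccccc45)cc3F)ccnc2cc1OCCCN1CCCCC1`, is not yet measured; it keeps the tail of compound 2 and carries the change (4-nitrophenyl in place of 2-fluorophenyl on an aromatic nitrogen). The same 4-nitrophenyl group is present in compound 1, whose value of 980 nM lies well above that of compound 2, but compound 1 also carries a different tail, so the share of the aryl change is uncertain. The step is expected to be a weakening one that stays smaller than the whole gap, and the expected step is a 2.8-fold higher number from compound 2 to compound 3 (0.45 log units; beyond the scatter). Compound 3 is therefore estimated at 450 nM, within 150 nM to 1400 nM.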

Compound 3, half-maximal inhibitory concentration: 1300 nM
Estimate against measurement, compound 3: 2.9-fold (0.46 log units) below; the range from low to high includes it.
By their numbers in this assay, from the lowest: compound 2; then compounds 1 and 3 (each within the scatter of the next).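

With the piperidin-1-yl tail held constant in this assay, placing 4-nitrophenyl instead of 2-fluorophenyl on the aromatic nitrogen gives an 8.1-fold higher number from compound 2 to compound 3 (0.91 log units; beyond the scatter), so this position is sensitive to the choice of aryl group. With 4-nitrophenyl held constant, the tail change gives a 1.3-fold higher number from compound 1 to compound 3 (0.12 log units; within the scatter), which means these two tails cannot be told apart when that aryl group is present. No available measurement explains the weakening seen with the aryl change.

Phenyl without a substituent, 4-fluorophenyl and 2-nitrophenyl would be needed to separate the effect of replacing fluorine with a nitro group from the effect of its location on the ring. On these data alone, it also remains open whether the two tails would still match when 2-fluorophenyl occupies this position.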